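A few compounds are considered here, and "the series" means these few. Any claim that something is new, unique, unknown or untested is made for them only; others in the source may bear on it.

Measured compounds:
- compound 1 `COc1ccccc1/C=c1/[nH]c(=O)/c(=C\c2ccccc2OC)n(C)c1=O`: "not active" (no number reported)
- compound 2 `C=CCn1c(=O)/c(=C\c2ccc(Cl)c(Cl)c2)[nH]c(=O)/c1=C\c1ccccc1OC`: "not active" (no number reported)
- compound 3 `C=CCn1c(=O)/c(=C\c2ccccc2OC)[nH]c(=O)/c1=C\c1ccccc1OC`: 21200 nM

In a functional assay on Huh-7 cells (Homo sapiens) for cytotoxicity, read by CCK-8 assay, with a stated time of 72 h (a higher number here means a weaker inhibitor, a lower number a stronger inhibitor), compound 1 is reported as "not active" (no number reported), with no number attached. Compound 2 is likewise reported in this assay as "not active" (no number reported), again without a number. Only compound 3 carries a number, giving 21200 nM in this assay, which places it at the weak end of what this read-out resolves. Within the data shown here, no pair among the three differs in one place, so no step size can be computed between them; compound 1 stands among the entries that returned no number at all.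

Compound 4 `COc1ccccc1/C=c1\c(=O)[nH]/c(=C/c2cccc(Cl)c2Cl)c(=O)n1C` is the unmeasured one. It differs from compound 1 by 2,3-dichlorophenyl in place of 2-methoxyphenyl on a double-bonded chain carbon bound to an aromatic carbon. Among the measured compounds shown here, no measured step describes a change of this kind, so its direction cannot be read from the numbers; the expectation is a step of no more than the usual scatter, with a real chance that no number is reported again. Compound 4 is estimated in this assay at 30000 nM, expected within 8000 nM to 100000 nM.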

Compound 4, half-maximal inhibitory concentration: 300 nM
The estimate for compound 4 lay 100-fold (2.00 log units) above the measured number; the measured number lies below the stated range.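

No step can be read between compound 1 and compound 4, as in this assay compound 1 gives "not active" (no number reported) and compound 4 gives 300 nM. Nothing measured here bears on the reason for this result. The compounds shown leave open how large the change from 2-methoxyphenyl to 2,3-dichlorophenyl is.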